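A few compounds are considered here, and "the series" means these few. Any claim that something is new, unique, unknown or untested is made for them only; others in the source may bear on it.

Measured so far:
- compound 1 `Oc1ccc(CC[C@@H](O)C[C@H](O)CCc2ccc(O)c(O)c2)cc1O`: 54 ug/mL
- compound 2 `OC[C@H]1O[C@@H](O[C@H](CCc2ccc(O)cc2)C[C@H](O)CCc2ccc(O)c(O)c2)[C@H](O)[C@@H](O)[C@@H]1O`: 155 ug/mL

In a functional assay on HSC-2 cells (Homo sapiens) for cytotoxicity, read by MTT assay (on this read-out higher numbers stand for weaker inhibition and lower numbers for stronger inhibition), compound 1 gives 54 ug/mL, the lowest of the two numbers. Compound 2 gives 155 ug/mL in this assay, a higher number, beyond the scatter; compound 2 differs from compound 1 in more than one place, so no single step can be read from the pair.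

Compound 3 `OC[C@H]1O[C@@H](O[C@H](CCc2ccc(O)c(O)c2)C[C@H](O)CCc2ccc(O)c(O)c2)[C@H](O)[C@@H](O)[C@@H]1O` is not yet measured. It differs from compound 1 by 3,4,5-trihydroxy-6-(hydroxymethyl)oxan-2-yl in place of hydrogen on an oxygen on a saturated carbon. Going by the values given here, with no directly comparable step in hand, the expectation is a moderate move toward weaker inhibition, a 2.0-fold higher number from compound 1 to compound 3 (0.31 log units; beyond the scatter), guided by compound 2 at 155 ug/mL. Compound 3 is estimated at 110 ug/mL, range 50 ug/mL to 250 ug/mL.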

Compound 3, half-maximal inhibitory concentration: 92 ug/mL
Beside the measured number, compound 3's estimate is 1.2-fold (0.08 log units) above it; measured number inside the range.
By their numbers in this assay, from the lowest: compounds 1, 3 and 2 (each within the scatter of the next, the first and the last beyond it).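

In this assay the 3,4,5-trihydroxy-6-(hydroxymethyl)oxan-2-yl group in place of hydrogen on this oxygen gives a 1.7-fold higher number from compound 1 to compound 3 (0.23 log units; within the scatter) and so cannot be told apart from the free hydroxy on this read-out. With that group kept, hydroxy in place of hydrogen on an aromatic carbon gives a 1.7-fold lower number from compound 2 to compound 3 (0.23 log units; within the scatter) and is equally unresolved. Nothing at hand accounts for either step.

From the compounds shown here alone, whether a smaller group on this oxygen, such as methyl or acetyl, would give a step beyond the scatter stays open. So does the outcome with an amine or a carboxylic acid there.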